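The compounds below may be only part of what the source reports. "The series", "measured", "known", "first", "only" and "open" are said of these compounds alone.

Compound 1, `N=C(N)c1ccc(O)c(CCCNC(=O)c2ccc(-c3ccccn3)s2)c1`: > 2900 nM
Compound 2, `N=C(N)c1ccc(O)c(/C=C/CNC(=O)c2ccc(-c3cccc(C(N)=O)c3)cc2)c1`: > 2900 nM

In an assay on isolated protein for inhibition of serine protease 1 (Homo sapiens) (a higher number here means a weaker inhibitor, a lower number a stronger inhibitor), compound 1 reaches only a limit, > 2900 nM, and no number. In this assay compound 2 likewise gives only a limit, > 2900 nM, rather than a measured inhibition constant. Compound 2 therefore stands nowhere distinct among the two values shown: both sit at the limit of > 2900 nM in this assay, at which 2 of the 2 values shown sit, and the two compounds cannot be ranked against each other on this evidence. Compound 3, `N=C(N)c1ccc(O)c(/C=C/CNC(=O)c2ccc(-c3ccc(C(N)=O)cc3)cc2)c1`, has not yet been measured in this assay. It shares every atom with compound 2, joined differently: 4-carbamoylphenyl in place of 3-carbamoylphenyl on an aromatic carbon. Among the compounds with values here, no step between measured compounds is available, so the size of this change cannot be read from the data. With both measured compounds at the limit, the expected result for compound 3 is that it stays near or at that limit, with the step that the limit leaves unreadable from compound 2 to compound 3 expected to be none beyond the usual scatter. The inhibition constant of compound 3 in this assay is accordingly estimated at 4000 nM, within a range from 1000 nM to 20000 nM.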

Compound 3, inhibition constant: 1400 nM
Beside the measured number, compound 3's estimate is 2.9-fold (0.46 log units) above it; low and high end bracket the measured number.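

In this assay, within the data shown here, the earlier compounds gave only limits, so nothing could be read about the carbamoyl group's place on this aromatic ring. Compound 3 now gives a first measured value, 1400 nM, and putting 4-carbamoylphenyl in place of 3-carbamoylphenyl produces an at least 2.0-fold lower number from compound 2 to compound 3 (0.31 log units; beyond the scatter), which shows that a change in how the same atoms are joined, with no heavy atom gained or lost, is enough to alter the result in this series. Compound 2 has only a limit, so this step gives a minimum size and not a full one: the limit of > 2900 nM in this assay, at which 2 of the 3 values shown sit.

Going by these compounds, it remains open whether another group at the same place, such as a carboxylic acid, a nitrile or an aminomethyl group, would give a lower or a higher number than compound 3 does. On these data alone, it is also open whether 4-carbamoylphenyl would give a similar step on a different part of the molecule, for example with the saturated chain of compound 1 in place of the double-bonded chain of compound 3.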